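The source may hold more compounds than are shown below. What is called first, only, known or untested is meant among the compounds shown, and "the series" means these compounds.

Measured in an ADME assay on HUVEC cells (Homo sapiens) for cytotoxicity, read by MTT assay, with a stated time of 72 h; a higher number here means a weaker inhibitor, a lower number a stronger inhibitor:
Compound 1 `CCn1ccnc1-c1cc(OC)c(OC)c(OC)c1`: "not determined" (no result reported)
Compound 2 `COc1cc(-c2nccn2-c2ccc3sccc3c2)cc(OC)c1OC`: "not determined" (no result reported)
Compound 3 `COc1cc(-c2nccn2-c2ccc3[nH]ccc3c2)cc(OC)c1OC`: 46700 nM

Compound 1 stands without a single number in this assay, and compound 2 shares that position, so compound 3 supplies the only figure. Compound 4 `COc1cc(-c2nccn2-c2cccc(C)c2)cc(OC)c1OC` has not yet been measured. The structural change is 3-methylphenyl in place of ethyl on an aromatic nitrogen: 3-methylphenyl takes the place of ethyl on an aromatic nitrogen. With no number for compound 1, the size of the step cannot be anchored there. The expectation rests instead on compound 3 at 46700 nM, which also carries a ring on that nitrogen, and no shift from that level beyond the scatter is expected in this assay. Compound 4 is expected at about 30000 nM, with an estimated range from 8000 nM to 100000 nM.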

Compound 4, half-maximal inhibitory concentration: > 100000 nM
Compound 4 was reported as a limit (the forecaster's own chance of this, stated with the estimate: 25%); at least 3.3-fold (0.52 log units) between middle value and limit.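

In this assay compound 4 gives > 100000 nM, a limit and not a number. Compound 1 has no single number, so no step can be read between compound 1 and compound 4. The compounds shown leave open what size of change 3-methylphenyl brings in place of ethyl.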